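This account rests on a few compounds, and the source may have more. Where it says the series, first, only, none or still open, it means among the compounds named here.

Measured so far in a functional assay on HeLa cells (Homo sapiens) for cytotoxicity; on this read-out higher numbers stand for lower toxicity in this test and lower numbers for higher toxicity in this test:
compound 1, `CCCCOC(=O)C(O)Cn1cnc2c(N)ncnc21`: 400 ug/mL
compound 2, `COCCOC(=O)C(O)Cn1cnc2c(N)ncnc21`: > 400 ug/mL
compound 3, `COC(=O)C(O)Cn1cnc2c(N)ncnc21`: > 400 ug/mL

The value of compound 2 is a limit of the assay and not a number. The value of compound 3 is likewise a limit of the assay, so compound 3 stands only at a limit, and (the limit of > 400 ug/mL in this assay, at which 2 of the 3 values shown sit). For the measured compounds named here, compound 1 is the only compound of the three that gives a number.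

Compound 4, `CCCCCOC(=O)C(O)Cn1cnc2c(N)ncnc21`, differs from compound 3 by butyl in place of hydrogen on a saturated chain carbon bound to an oxygen next to a carbonyl group.

Of the measured steps, the one that bears most directly on this change runs the other way along the same chain: a number no lower from compound 1 to compound 3 (the limit leaves the size open). The remaining steps, a number no lower from compound 1 to compound 2 (the limit leaves the size open) and a step that the two limits leave unreadable from compound 2 to compound 3, touch the same position but do not read in size. Nothing in the series shows a step beyond the scatter in either direction. Going by the values given here, compound 4 extends the same chain further than compound 1, and compound 1 is the only compound that returns a number, so compound 4 is expected to return a number near that of compound 1 rather than a limit. The expected step is an at least 1.3-fold lower number from compound 3 to compound 4 (0.12 log units; that floor lies within the scatter). Compound 4 is estimated at 300 ug/mL, in the range 100 ug/mL to 400 ug/mL.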

Compound 4, minimum cytotoxic concentration: > 400 ug/mL
Compound 4 ended at the assay's limit; the forecaster's own chance of this, stated with the estimate: 35%; middle value at least 1.3-fold (0.12 log units) from the limit.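

In this assay the value of compound 4 is a limit of the assay and not a number, so the pentyl chain on this saturated chain carbon gives no reading. For the compounds shown here, compound 1 therefore remains the only compound with a number, and the one step with a readable direction is a number no lower from compound 1 to compound 4 (the limit leaves the size open), so extending the chain beyond that of compound 1 brings no lower number on this read-out. The steps to compound 4 from compound 2 and compound 3 cannot be read, and the series now sits almost entirely at one limit: the limit of > 400 ug/mL in this assay, at which 3 of the 4 values shown sit.

On these data alone, with nearly all values at that limit, the size of every step at this position stays open, as does whether any group here can lower the number beyond the scatter. A longer chain such as octyl, or a chain ending in an amine or a carboxylic acid, would show whether the number of compound 1 is an isolated reading or part of a trend along the chain.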